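From 3-bromophenyl to 4-methylphenyl on a shared core

The source may report more compounds than this note shows. Statements on the series, on what has been measured and on what is new or still open speak of the compounds shown alone.

In a functional assay on B16-F10 cells (Mus musculus) for cytotoxicity (on this read-out higher numbers stand for weaker inhibition and lower numbers for stronger inhibition), compound 2 `O=c1oc2ccccc2c2nc3c(ccc4cc[nH]c43)c(-c3cccc(Br)c3)c12` gives 70700 nM, level with compound 1 `O=c1oc2ccccc2c2nc3c(ccc4cc[nH]c43)c(-c3cccc4ccccc34)c12` at 70700 nM and compound 3 `O=c1oc2ccccc2c2nc3c(ccc4cc[nH]c43)c(-c3ccc(O)cc3)c12` at 70700 nM. Compound 4 `Cc1ccc(-c2c3ccc4cc[nH]c4c3nc3c2c(=O)oc2ccccc23)cc1` keeps the shared core and changes one group: 4-methylphenyl in place of 3-bromophenyl on an aromatic carbon. It carries 4-methylphenyl in place of 3-bromophenyl on an aromatic carbon, opposite the ring nitrogen. Three measured swaps of the group on this carbon bear on the change: no change at the digits printed from compound 1 to compound 2 (within the scatter), no change at the digits printed from compound 1 to compound 3 (within the scatter) and no change at the digits printed from compound 2 to compound 3 (within the scatter). None of them went beyond the scatter, so no step beyond the scatter is expected here, in either direction. The estimated step is no change at the digits printed from compound 2 to compound 4 (within the scatter). Compound 4 is expected at 70700 nM, with an estimated range from 30000 nM to 100000 nM.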

Compound 4, half-maximal inhibitory concentration: 70700 nM
Beside the measured number, compound 4's estimate shows no gap at the digits printed; the range from low to high includes it.
By their numbers in this assay, from the lowest: compounds 1, 2, 3 and 4 (each within the scatter of the next).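

In this assay the 4-methylphenyl group joins the earlier groups with no separation (no change at the digits printed from compound 2 to compound 4 (within the scatter)), and the same holds against the 4-hydroxyphenyl compound (no change at the digits printed from compound 3 to compound 4 (within the scatter)) and the naphthalen-1-yl compound (no change at the digits printed from compound 1 to compound 4 (within the scatter)). All four groups on this carbon, opposite the ring nitrogen, now read alike, including the pair that differs only in methyl versus hydroxy. No measured evidence here offers a reason for this flat result. Still open, as far as these compounds go, is whether a group with no aromatic ring, such as an amine or a carboxylic acid on a longer chain, would read differently on this carbon.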